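The source may hold more compounds than are shown below. What is called first, only, known or untested is meant among the compounds shown, and "the series" means these compounds.

Working notes on the series. Compound 1 `CCOC(=O)C1=Cc2ccccc2OC1(OCc1cn(CC(=O)Nc2cccc(Cl)c2)nn1)C(F)(F)F` and compound 2 `CCOC(=O)C1=Cc2ccccc2OC1(OCc1cn(CC(=O)Nc2ccc(OC)cc2)nn1)C(F)(F)F` share one core and differ only in the aryl group on the amide-type nitrogen. In a functional assay on DU-145 cells (Homo sapiens) for inhibition, read by MTT assay, with a stated time of 24 h (on this read-out lower numbers stand for stronger inhibition and higher numbers for weaker inhibition), compound 1 gives 10100 nM, and in this assay compound 2 gives 32700 nM. Within the data shown here, compound 2 therefore holds the highest of the two numbers so far; its nearest neighbour is compound 1, reached through a 3.2-fold higher number from compound 1 to compound 2 (0.51 log units; beyond the scatter).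

Compound 3 `CCOC(=O)C1=Cc2ccccc2OC1(OCc1cn(-c2ccc(F)c(Cl)c2)nn1)C(F)(F)F` is not yet measured. The change from compound 2 is 3-chloro-4-fluorophenyl in place of ((4-methoxyphenyl)carbamoyl)methyl on an aromatic nitrogen. Among the measured compounds shown here, only one measured step exists to bear on this, a 3.2-fold higher number from compound 1 to compound 2 (0.51 log units; beyond the scatter), and it bears loosely: it exchanges one aryl for another while keeping the ((aryl)carbamoyl)methyl link, whereas compound 3 drops that link altogether and sets a halogenated aryl directly on the aromatic nitrogen. What the step does show is that the chlorine-bearing aryl of compound 1 gave the lower number. On that slim basis the step of a 2.7-fold lower number from compound 2 to compound 3 (0.44 log units; beyond the scatter) is expected to run downward from compound 2 toward the level of compound 1, with wide uncertainty. For compound 3 the estimated value in this assay is 12000 nM, expected within 3000 nM to 50000 nM.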

Compound 3, half-maximal inhibitory concentration: 21500 nM
Compound 3: middle estimate off by 1.8-fold (0.25 log units), on the low side; the measured number falls inside the stated range.
By their numbers in this assay, from the lowest: compound 1; then compounds 3 and 2 (each within the scatter of the next).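

Replacing the ((4-methoxyphenyl)carbamoyl)methyl group on the aromatic nitrogen with 3-chloro-4-fluorophenyl gives a 1.5-fold lower number from compound 2 to compound 3 (0.18 log units; within the scatter) in this assay, so at this position the loss of the whole carbamoylmethyl link, amide hydrogen included, leaves compound 2 and compound 3 indistinguishable on this read-out. The same replacement made on ((3-chlorophenyl)carbamoyl)methyl gives a 2.1-fold higher number from compound 1 to compound 3 (0.33 log units; beyond the scatter), which leaves compound 1 with the lowest number of the three, its steps to compound 2 and compound 3 both being beyond the scatter, and shows that a chlorine on the aryl does not by itself bring a compound to the level of compound 1, as compound 3 also carries one. No supporting data on any property of these groups are at hand to explain these numbers.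

On these data alone, the link and the aryl substitution change together in both steps, so the share of each in these numbers stays open. Also open, as far as these compounds go, is how an amine or a carboxylic acid on the aryl, or a longer chain on the aromatic nitrogen, would read in this assay.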